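This account rests on a few compounds, and the source may have more. Where it says the series, first, only, none or still open, it means among the compounds named here.

Three compounds have been measured in an ADME assay on Vero cells (Chlorocebus sabaeus) for cytotoxicity, with a stated time of 72 h; a lower number here means a stronger inhibitor, a higher number a weaker inhibitor:

Compound 1, `CCOC(=O)c1cc(-c2cccc(OCc3cccc(F)c3)c2)on1`, gives > 128000 nM, which is a limit of the assay and not a number.
Compound 2, `CCOC(=O)c1cc(-c2cccc(OCc3cccc(Cl)c3)c2)on1`, gives > 128000 nM, again a limit of the assay.
Compound 3, `CCOC(=O)c1cc(-c2cccc(OCc3cccc(OC(F)(F)F)c3)c2)on1`, gives 101000 nM.

Among the compounds with values here, compound 3 thus holds the only true number among the three; the other two values sit at the limit, as the limit of > 128000 nM in this assay, at which 2 of the 3 values shown sit, records. All three share the same core and differ only in one group on the six-membered aromatic ring of carbon only.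

Compound 4, `CCOC(=O)c1cc(-c2cccc(OCc3cccc([N+](=O)[O-])c3)c2)on1`, has not yet been measured. It differs from compound 3 by nitro in place of trifluoromethoxy on an aromatic carbon. Within the data shown here, two measured steps bear on this change, both ending in compound 3: an at least 1.2-fold lower number from compound 1 to compound 3 (0.10 log units; that floor lies within the scatter) and an at least 1.2-fold lower number from compound 2 to compound 3 (0.10 log units; that floor lies within the scatter). Each is read against a limit, and each floor lies within the usual scatter, so neither shows a clear movement when the group on that ring is exchanged. The step from compound 1 to compound 2 cannot be read at all because the limit of > 128000 nM in this assay, at which 2 of the 3 values shown sit, caps both values.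

With nothing beyond the scatter seen for earlier exchanges of this group, compound 4 is expected to stay close to compound 3, with a step of a 1.1-fold higher number from compound 3 to compound 4 (0.04 log units; within the scatter) in this assay. The estimate for compound 4 is 110000 nM, between 55000 nM and 200000 nM, and a value reported only as a limit would not be surprising.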

Compound 4, half-maximal inhibitory concentration: > 128000 nM
Compound 4 gave a limit, no number; the forecaster's own chance of this, stated with the estimate: 45%; middle value at least 1.1-fold (0.06 log units) from the limit.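

In this assay, nitro in place of trifluoromethoxy gives an at least 1.2-fold higher number from compound 3 to compound 4 (0.10 log units; that floor lies within the scatter); this step is read against the limit of compound 4, so it shows no clear change at this place on the ring. Nitro, built from nitrogen and oxygen and carrying a double bond outside aromatic rings, now joins fluoro in compound 1 and chloro in compound 2 at the limit, and trifluoromethoxy in compound 3 is the one group of the four that goes against this by giving a true number. The steps from compound 1 and from compound 2 to compound 4 cannot be read, because both ends of each step are capped by the same limit: the limit of > 128000 nM in this assay, at which 3 of the 4 values shown sit.

On these data alone, whether an amine, a carboxylic acid or a longer chain at this place on the ring would give a number clearly lower than that of compound 3 stays open. Also open, as far as these compounds go, is how compound 1, compound 2 and compound 4 compare with one another, and what a change to the ethyl ester of the shared core would do in this assay.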